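The source may report more compounds than this note shows. Statements on the series, on what has been measured and on what is new or still open speak of the compounds shown alone.

Compound 2 `CCCCCCCCc1cn(Cc2cc(=O)oc3cc(O)ccc23)nn1` carries the shared core with a heptyl chain on its triazole, and in a functional assay on CFPAC-1 cells (Homo sapiens) for inhibition, read by MTT assay, with a stated time of 72 h (on this read-out lower numbers stand for stronger inhibition and higher numbers for weaker inhibition), compound 2 gives 62700 nM. Among the two results seen, compound 2 holds the only number; the other result is a limit. Its neighbour, compound 1 `CCCCCCc1cn(Cc2cc(=O)oc3cc(O)ccc23)nn1`, differs by a shorter chain, and in this assay compound 1 reaches only the limit > 100000 nM, which is the limit of > 100000 nM in this assay, at which 1 of the 2 values shown sits. The step of an at least 1.5-fold lower number from compound 1 to compound 2 (0.20 log units; that floor lies within the scatter) is therefore at least that large, though its floor lies within the scatter.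

Compound 3 `O=c1cc(Cn2cc(CSC(=S)N3CCOCC3)nn2)c2ccc(O)cc2o1` changes a different part of the molecule: a group of 9 heavy atoms (5 carbon, 1 nitrogen, 1 oxygen, 2 sulfur; one six-membered non-aromatic ring with 2 hetero atoms) in place of a group of 7 heavy atoms (7 carbon; no ring), on a saturated chain carbon bound to an aromatic carbon. Among the compounds with values here, no measured step bears on this change; the only step seen concerns chain length, not the replacement of the whole chain by a ring-bearing group, so nothing measured points to either direction. With that, compound 3 is expected to stay near compound 2, and the step of a 1.3-fold lower number from compound 2 to compound 3 (0.10 log units; within the scatter) is estimated to be small, with a wide range around it. In this assay compound 3 is estimated at 50000 nM, between 8000 nM and 200000 nM.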

Compound 3, half-maximal inhibitory concentration: 56300 nM
Compound 3: middle estimate off by 1.1-fold (0.05 log units), on the low side; the measured number falls inside the stated range.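

In this assay, the ring-bearing group with its two sulfur atoms and 3 hydrogen-bond acceptors takes the place of the heptyl chain on a saturated chain carbon bound to an aromatic carbon, and the step is a 1.1-fold lower number from compound 2 to compound 3 (0.05 log units; within the scatter). This shows what the chain-length step alone could not: at this place, a group with a very different make-up from a plain carbon chain gives a value that stays within the scatter of the heptyl compound, and the step of an at least 1.7-fold lower number from compound 1 to compound 3 (0.24 log units; that floor lies within the scatter) likewise has only a floor that lies within the scatter. Compound 1 stands at a limit and not at a number, so neither step that starts from it has a known size: the limit of > 100000 nM in this assay, at which 1 of the 3 values shown sits.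

Going by these compounds, whether an amine, a carboxylic acid or a longer chain at this place would carry the value beyond the scatter remains open. The parts played by the six-membered ring and by the sulfur atoms also stay unseparated, as no compound shown carries one without the other.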